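A few compounds are considered here, and "the series" means these few. Any claim that something is new, unique, unknown or untested is made for them only; others in the source may bear on it.

Measured series:
compound 1 `COc1cc(/C=N/NC(=O)c2cnccn2)ccc1O` gives 34.7% in a functional assay on the whole organism (strain Swiss) for inhibition, with Mus musculus as the target, with stated times of 40 min and 6 h, at a dose of 100 mg/kg by the oral route; a higher number here means more inhibition at the dose given (going by the name of the read-out), a lower number less inhibition
compound 2 `O=C(N/N=C/c1ccc(-c2ccccc2)cc1)c1cnccn1` gives 14.4%
compound 3 `COc1ccc(/C=N/NC(=O)c2cnccn2)cc1OC` gives 51.3%

Compound 3 stands highest of the three, with compound 1 nearest and compound 2 furthest, both steps to it beyond the scatter. Compound 4 `COc1ccc(/C=N/NC(=O)c2cnccn2)cc1O` differs from compound 3 by hydrogen in place of methyl on an oxygen on an aromatic ring. Among the measured compounds shown here, the one measured step that bears on this is the reverse of it: a number 16.6 percentage points higher from compound 1 to compound 3 (beyond the scatter). Undoing a change of that kind is therefore expected to give a step of comparable size downward in this assay, with the caveat that no measured pair tests this exact oxygen. The expected step is a number 16.3 percentage points lower from compound 3 to compound 4 (beyond the scatter). Compound 4 is thus estimated at 35%, between 20% and 50%.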

Compound 4, a percentage reported as inhibition, in the whole organism at one dose (the size of the read-out at that dose, not a potency): 50.4%
Compound 4: the middle estimate sits 15.4 percentage points below what was measured; measured number outside the range, above it.
By their numbers in this assay, from the lowest: compound 2; then compound 1; then compounds 4 and 3 (each within the scatter of the next).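

In this assay the change of methoxy to hydroxy on this oxygen gives a number 0.9 percentage points lower from compound 3 to compound 4 (within the scatter), so the methyl here is dispensable at this dose. The same kind of change on the other oxygen gave a step beyond the scatter (a number 16.6 percentage points higher from compound 1 to compound 3 (beyond the scatter)), so the two oxygens of compound 3 do not behave alike. No evidence at hand explains this difference.

Still open, from the compounds shown here alone, is what an amine, a carboxylic acid or a longer chain such as ethoxy would give in place of hydroxy on this oxygen-bearing carbon.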